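The source may hold more compounds than are shown below. What is called first, only, known or untested is meant among the compounds shown, and "the series" means these compounds.

Of the compounds shown here, three that share one core have been measured in an ADME assay on L6 cells (Rattus norvegicus) for cytotoxicity, read by resazurin assay, with a stated time of 72 h; on this read-out lower numbers stand for stronger inhibition and higher numbers for weaker inhibition. Compound 1 `CN1CCN(CCC(=O)N2CCC3(N(C)C)CC(c4ccccc4)C2C(c2ccccc2)C3)CC1` gives 128000 nM, compound 2 `CN1CCN(CCC(=O)N2CCC3(N4CCCCC4)CC(c4ccccc4)C2C(c2ccccc2)C3)CC1` gives 120000 nM, and compound 3 `CN1CCN(CC(=O)N2CCC3(N4CCCC4)CC(c4ccccc4)C2C(c2ccccc2)C3)CC1` gives 69100 nM. These values all lie within the usual scatter of one another, so compound 3 cannot be told apart from the other two.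

Compound 4 `CN1CCN(CCC(=O)N2CCC3(N4CCCC4)CC(c4ccccc4)C2C(c2ccccc2)C3)CC1` has not yet been measured. Its difference from compound 3 is (4-methylpiperazin-1-yl)methyl in place of 4-methylpiperazin-1-yl on a saturated chain carbon bound to a carbonyl carbon.

For the measured compounds named here, no measured step shows this change directly. Going by the values given here, the only measured step is a 1.1-fold lower number from compound 1 to compound 2 (0.03 log units; within the scatter), a swap elsewhere in the molecule, and it stays within the scatter. Compounds 1 and 2 do, however, carry the same (2-(4-methylpiperazin-1-yl)ethyl)carbonyl as compound 4, so their values are a useful guide. No change beyond the scatter is therefore expected in this assay.

The estimated step is a 1.4-fold higher number from compound 3 to compound 4 (0.16 log units; within the scatter), which would stay within the scatter. For compound 4 the expected value is 100000 nM, with an estimated range from 55000 nM to 180000 nM.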

Compound 4, half-maximal inhibitory concentration: 75400 nM
Compound 4: middle estimate off by 1.3-fold (0.12 log units), on the high side, within the range that was stated.
By their numbers in this assay, from the lowest: compounds 3, 4, 2 and 1 (each within the scatter of the next).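

In this assay, the change at the saturated chain carbon bound to a carbonyl carbon, from 4-methylpiperazin-1-yl to (4-methylpiperazin-1-yl)methyl, now has a direct measurement: a 1.1-fold higher number from compound 3 to compound 4 (0.04 log units; within the scatter), so this small extension of the chain leaves the number within the scatter. With the chain of compound 4 held fixed, the group on the saturated ring carbon can also be compared, and pyrrolidin-1-yl gives a 1.6-fold lower number from compound 2 to compound 4 (0.20 log units; within the scatter) against piperidin-1-yl and a 1.7-fold lower number from compound 1 to compound 4 (0.23 log units; within the scatter) against dimethylamino, so these three amines cannot be told apart here. No measured evidence on these compounds bears on this result.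

The compounds shown leave open whether a longer chain, such as 3-(4-methylpiperazin-1-yl)propyl, would stay within the scatter. As far as these compounds go, it is also open whether morpholin-4-yl or a carboxylic acid in place of 4-methylpiperazin-1-yl would do so.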